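An Added Ether Oxygen in the Chain of Compound 2

The source may report more compounds than this note shows. Statements on the series, on what has been measured and on what is new or still open speak of the compounds shown alone.

In a functional assay on HT-29 cells (Homo sapiens) for inhibition, read by sulforhodamine B assay, with a stated time of 72 h (a higher number here means a weaker inhibitor, a lower number a stronger inhibitor), compound 1 `C#Cc1cccc(Nc2ncnc3cc(OCCOCCn4ccnc4[N+](=O)[O-])c(OC)cc23)c1` gives 8770 nM and compound 2 `COc1cc2c(Nc3cccc(Br)c3)ncnc2cc1OCCCCn1ccnc1[N+](=O)[O-]` gives 4020 nM as the lower of the two numbers, a gap beyond the scatter. Compound 3 `COc1cc2c(Nc3cccc(Br)c3)ncnc2cc1OCCOCCn1ccnc1[N+](=O)[O-]` is still unmeasured. It carries 2-(2-nitro-1H-imidazol-1-yl)ethoxy in place of 2-(2-nitro-1H-imidazol-1-yl)ethyl on a saturated chain carbon, a change counted as 2-(2-nitro-1H-imidazol-1-yl)ethoxy in place of 2-(2-nitro-1H-imidazol-1-yl)ethyl on a saturated chain carbon, two bonds along the chain from an oxygen on an aromatic ring here. Going by the values given here, no measured pair shows this change. The expected step is small and within the scatter, estimated as a 1.4-fold higher number from compound 2 to compound 3 (0.14 log units; within the scatter) toward a higher number. For compound 3 the estimated value is 5500 nM with an expected range from 2500 nM to 12000 nM in all.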

Compound 3, half-maximal inhibitory concentration: 10800 nM
Compound 3: middle estimate off by 2.0-fold (0.29 log units), on the low side; the range from low to high includes it.
By their numbers in this assay, from the lowest: compound 2; then compounds 1 and 3 (each within the scatter of the next).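

In this assay the swap of 2-(2-nitro-1H-imidazol-1-yl)ethoxy for 2-(2-nitro-1H-imidazol-1-yl)ethyl on this saturated chain carbon gives a 2.7-fold higher number from compound 2 to compound 3 (0.43 log units; beyond the scatter) and so shows that this place in the chain responds to the added ether oxygen. Bromo in place of ethynyl on an aromatic carbon gives a 1.2-fold higher number from compound 1 to compound 3 (0.09 log units; within the scatter) and leaves the two compounds level within the scatter. Nothing shown here explains either step. As far as these compounds go, whether an amine or a longer chain at this place would shift the number stays open, as does whether the oxygen step would be the same with ethynyl in place of bromo.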